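Methoxy-to-hydroxy step on the pyrazole series, compound 2 to compound 3

The source may hold more compounds than are shown below. What is called first, only, known or untested is meant among the compounds shown, and "the series" means these compounds.

Of the compounds shown here, two of the shared core have numbers so far. Compound 1 `O=C(Nc1cccc(-n2cc(-c3ccncc3)c(-c3ccc(Cl)c(O)c3)n2)c1)Nc1cccc(C(F)(F)F)c1` gives 7900 nM in a functional assay on COLO 205 cells (Homo sapiens) for inhibition, read by sulforhodamine B assay, with a stated time of 48 h; a lower number here means a stronger inhibitor of growth, a higher number a weaker inhibitor of growth. Compound 2 `COc1cc(-c2nn(-c3cccc(NC(=O)Nc4cc(C(F)(F)F)cc(C(F)(F)F)c4)c3)cc2-c2ccncc2)ccc1Cl` gives 847 nM in this assay, the lower of the two numbers; compound 1 differs from it in more than one place, so the gap cannot be read as one change. Compound 3 `O=C(Nc1cccc(-n2cc(-c3ccncc3)c(-c3ccc(Cl)c(O)c3)n2)c1)Nc1cc(C(F)(F)F)cc(C(F)(F)F)c1` differs from compound 2 by hydrogen in place of methyl on an oxygen on an aromatic ring. Within the data shown here, no single step of this kind has been measured here; the expected step of a 1.8-fold higher number from compound 2 to compound 3 (0.25 log units; within the scatter) is a modest rise, barely beyond the scatter. Compound 3 is estimated at 1500 nM, with a range from 400 nM to 6000 nM.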

Compound 3, concentration for 50% growth inhibition: 853 nM
Compound 3: middle estimate off by 1.8-fold (0.25 log units), on the high side; the measured number falls inside the stated range.
By their numbers in this assay, from the lowest: compounds 2 and 3 (each within the scatter of the next); then compound 1.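

In this assay, methoxy to hydroxy gives a 1.0-fold higher number from compound 2 to compound 3 (0.00 log units; within the scatter), so at this oxygen the methyl can give way to hydrogen with no separation of the numbers. With hydroxy held constant, trifluoromethyl in place of hydrogen on an aromatic carbon gives a 9.3-fold lower number from compound 1 to compound 3 (0.97 log units; beyond the scatter), which locates the earlier gap between compound 1 and compound 2 at that carbon, not at the oxygen. No measurement here offers a reason for either step.

Going by these compounds, whether an ethoxy group or an amine at this place reads the same stays open. Each step also rests on a single pair.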